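A few compounds are considered here, and "the series" means these few. Any claim that something is new, unique, unknown or untested is made for them only; others in the source may bear on it.

Measured so far in a functional assay on the whole organism (plasma, strain Sprague-Dawley) with Rattus norvegicus as the target, with a stated time of 2 h, at a dose of 100 mg/kg by the oral route; a higher number here means a stronger effect of the compound at the dose given, a lower number a weaker effect:

compound 1, `COc1ccc(C(/N=C2\CCC(C(C)(C)C)CCN2)C2CC2)cc1`: 17%
compound 2, `c1ccc(C(/N=C2\CCCCCN2)C2CCCC2)cc1`: 46%

Of these two numbers, compound 2 stands highest. Among the compounds with values here, its only neighbour is compound 1, whose value lies lower by a margin beyond the usual scatter of this assay, so the two compounds are clearly set apart. Within the data shown here, they differ in several places at once, however, and no pair of measured compounds differs in just one place, so no measured step can be read from them.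

Compound 3 `c1ccc(C(/N=C2\CCCCCN2)c2cccs2)cc1` is the next compound to be measured in this assay. It departs from compound 2 in a single place: thiophen-2-yl in place of cyclopentyl on a saturated chain carbon bound to an aromatic carbon and a double-bonded nitrogen. Among the measured compounds shown here, nothing among the measured compounds speaks to this exchange, so any expectation for it rests on the value of compound 2 alone. The account expects at most a modest step downward, one that may well stay within the scatter. The step from compound 2 to compound 3 is expected to be a number 8 percentage points lower from compound 2 to compound 3 (within the scatter). Compound 3 is therefore estimated at 38%, with a range from 12% to 64%.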

Compound 3, a percentage reported as inhibition, in the whole organism at one dose (the size of the read-out at that dose, not a potency): 50%
The estimate for compound 3 lay 12 percentage points below the measured number; the range from low to high includes it.
By their numbers in this assay, from the lowest: compound 1; then compounds 2 and 3 (each within the scatter of the next).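

In this assay, thiophen-2-yl in place of cyclopentyl on a saturated chain carbon bound to an aromatic carbon and a double-bonded nitrogen gives a number 4 percentage points higher from compound 2 to compound 3 (within the scatter), so the two compounds cannot be told apart. Within the data shown here, this is the first single-place exchange, and it shows that this place can take a five-membered aromatic ring with one sulfur atom and one hydrogen-bond acceptor instead of a five-membered carbon ring with no acceptor, with no change beyond the scatter at this dose; compound 1 differs from both in several places, so no step to it can be read. No measurement at hand explains why the exchange leaves the read-out within the scatter.

The compounds shown leave open whether this place would also take a phenyl ring, a much smaller methyl group, or a chain ending in an amine or a carboxylic acid. They also leave open whether the same exchange would behave alike on the core of compound 1, and, as each number comes from a single dose, whether compound 2 and compound 3 would still match at other doses.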